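Swapping a Hexyl Ketone for a Pentyl Amide

The source may hold more compounds than are shown below. What is called first, only, known or untested is meant among the compounds shown, and "the series" means these compounds.

Of the compounds shown here, two have been measured so far in a functional assay for inhibition, with stated times of 20 min and 60 min, tested at 500 uM; on this read-out higher numbers stand for a stronger effect at the one concentration tested and lower numbers for a weaker effect. Compound 1 `O=C(CCc1ccc(O)c(O)c1)OCCc1ccc(O)c(O)c1` gives 49% in this assay. Compound 2 `CCCCCCC(=O)/C=C/c1ccc(O)c(O)c1` gives 62% in this assay. Compound 2 stands highest of the two numbers, and its nearest neighbour, compound 1, lies lower by an amount beyond the usual scatter of repeated measurements of this kind.

Compound 3 `CCCCCNC(=O)/C=C/c1ccc(O)c(O)c1` has not yet been measured. Relative to compound 2 it differs in one place: pentylamino in place of hexyl on a carbonyl carbon. The carbonyl stays, hexyl leaves, pentylamino enters, and with it one hydrogen-bond donor where compound 2 had none. Among the measured compounds shown here, no pair among the measured compounds shows what such a change does on this read-out, so no measured step can guide the guess; compound 1 and compound 2 differ in several places at once, and their values can only be read side by side.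

The step that this estimate means, a number 7 percentage points lower from compound 2 to compound 3 (within the scatter), is expected to be small, within the scatter or slightly downward. Compound 3 is therefore expected to give about 55%, with a range from 35% to 75%.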

Compound 3, a percentage reported as inhibition, at one concentration (the size of the read-out at that concentration, not a potency): 53%
The estimate for compound 3 lay 2 percentage points above the measured number, and the stated range covers the measured number.
By their numbers in this assay, from the lowest: compounds 1, 3 and 2 (each within the scatter of the next, the first and the last beyond it).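

In this assay, among the compounds shown here, putting pentylamino in place of hexyl on a carbonyl carbon gives a number 9 percentage points lower from compound 2 to compound 3 (within the scatter) and is the first measured step that changes a single place in these compounds. At this one tested concentration, then, a change that keeps 6 heavy atoms, brings in a nitrogen and adds 1 hydrogen-bond donor moves the read-out by no more than repeated measurements of this kind can vary, so the ketone and the amide cannot be told apart here. No supporting measurement is available to explain this outcome.

A single step cannot show whether the amide hydrogen or the chain length matters more at this carbonyl carbon, and a methyl(pentyl)amino group, a longer octylamino chain or a carboxylic acid in the same place would test different parts of that question. As far as these compounds go, each compound was read at only one concentration, so whether the ketone and the amide would differ in the strength of their effect at any other concentration also remains open.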